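Amino-acid esters of a fluorinated nucleoside in pancreatic cells

The source may hold more compounds than are shown below. What is called first, only, known or untested is meant among the compounds shown, and "the series" means these compounds.

Compound 1 `N[C@@H](CC(=O)OC[C@H]1O[C@@H](n2cc(F)c(=O)[nH]c2=O)C[C@@H]1O)C(=O)O` and compound 2 `CC(C)[C@H](N)C(=O)OC[C@H]1O[C@@H](n2cc(F)c(=O)[nH]c2=O)C[C@@H]1O` share one core and differ in the acyl group on the ester; compound 3 `N[C@@H](CC(=O)O[C@H]1C[C@H](n2cc(F)c(=O)[nH]c2=O)O[C@@H]1CO)C(=O)O` and compound 4 `CC(C)[C@H](N)C(=O)O[C@H]1C[C@H](n2cc(F)c(=O)[nH]c2=O)O[C@@H]1CO` carry the same pair of acyl groups on a core that is built from the same atoms joined differently. The difference between the two cores is not broken down here.

In a functional assay on MIA PaCa-2 cells (Homo sapiens) for inhibition, read by MTT assay, with a stated time of 24 h (on this read-out higher numbers stand for weaker inhibition of growth and lower numbers for stronger inhibition of growth), compound 1 gives 3600000 nM. Compound 2 gives 4200000 nM in this assay, and the change between them 1-amino-2-methylpropyl in place of 2-amino-2-carboxyethyl on a carbonyl carbon produces a 1.2-fold higher number from compound 1 to compound 2 (0.07 log units; within the scatter). Compound 3 gives 4100000 nM in this assay, a number that sits within the scatter of both compound 1 and compound 2, so no order among the three is claimed.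

The change from compound 3 to compound 4 is the same change 1-amino-2-methylpropyl in place of 2-amino-2-carboxyethyl on a carbonyl carbon made on the other core, and it is the second time it occurs among these compounds. Since the first occurrence, from compound 1 to compound 2, stayed within the scatter, and since compound 3 already lies next to compound 2, the step from compound 3 to compound 4 is expected to be a 1.1-fold higher number from compound 3 to compound 4 (0.04 log units; within the scatter) in this assay, again within the scatter. Among the measured compounds shown here, on this basis compound 4 is expected to give about 4500000 nM, most likely between 2000000 nM and 10000000 nM, because the only measured example of this change a 1.2-fold higher number from compound 1 to compound 2 (0.07 log units; within the scatter) was small.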

Compound 4, concentration for 50% growth inhibition: 2600000 nM
Estimate against measurement, compound 4: 1.7-fold (0.24 log units) above; the measured number falls inside the stated range.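

In this assay, the step of a 1.6-fold lower number from compound 3 to compound 4 (0.20 log units; within the scatter) stays within the scatter, as the first occurrence of this change did. Set side by side, the two steps cannot be told apart, whatever their apparent direction: the same change on two cores in this assay, a 1.2-fold higher number (0.07 log units; within the scatter) from compound 1 to compound 2 and a 1.6-fold lower number (0.20 log units; within the scatter) from compound 3 to compound 4, 1.8-fold (0.26 log units) apart, within the scatter of two such steps. Among the compounds shown here, this shows that placing 1-amino-2-methylpropyl in place of 2-amino-2-carboxyethyl on a carbonyl carbon left the read-out within the scatter on both cores, so the two cores give no sign of treating this change differently, but it does not show that a real effect of fixed size carries from one core to the other, as neither step rises above the scatter and only two cores and this one cell assay are represented.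

The compounds shown leave open whether any acyl group on these cores can move the number in this assay beyond the scatter, for instance a plain acetyl group with no amine and no carboxylic acid, or a longer chain ending in an amine. Going by these compounds, they also leave open how these esters compare with the parent nucleoside carrying a free hydroxyl at the same place, so the contribution of the ester itself remains unknown.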